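The source may hold more compounds than are shown below. What is called first, only, known or untested is meant among the compounds shown, and "the series" means these compounds.

Measured compounds in a functional assay on HeLa cells (Homo sapiens) for inhibition, read by cell counting, with a stated time of 96 h; on this read-out lower numbers stand for stronger inhibition and higher numbers for weaker inhibition:

Compound 1, `CCN(CC)CN1C(=O)/C(=N/NC(=S)Nc2ccccc2)c2cc(Cl)ccc21`, gives 34000 nM.
Compound 2, `CCN(CC)CN1C(=O)/C(=N/NC(N)=S)c2cc(Cl)ccc21`, gives 44000 nM.
Compound 3, `CCN(CC)CN1C(=O)/C(=N/NC(=S)Nc2ccccc2)c2ccccc21`, gives 8300 nM.

Compound 3 stands lowest of the three numbers. Its nearest neighbour is compound 1, separated by the step of a 4.1-fold lower number from compound 1 to compound 3 (0.61 log units; beyond the scatter), which is beyond the scatter; compound 2 lies further off still, and its value and that of compound 3 are well apart.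

Compound 4, `CCN(CC)CN1C(=O)/C(=N/NC(N)=S)c2ccccc21`, differs from compound 3 in one place: hydrogen in place of phenyl on an amide-type nitrogen. Cut one bond further out the change reads anilino to amino, sitting on the amide-type nitrogen whose other neighbour is the thiocarbonyl carbon.

Among the measured compounds shown here, one measured step bears on this change directly, since it is the same exchange made on the chloro-bearing pair: a 1.3-fold higher number from compound 1 to compound 2 (0.11 log units; within the scatter). That step lies within the scatter. The other step, a 4.1-fold lower number from compound 1 to compound 3 (0.61 log units; beyond the scatter), concerns the chloro on an aromatic carbon and not this nitrogen, so it says nothing about the present change.

For compound 4 the expected step in this assay is therefore small, at most a slight move to a higher number, and the estimate is a 1.3-fold higher number from compound 3 to compound 4 (0.12 log units; within the scatter). Compound 4 is expected to give about 11000 nM, with a range from 5000 nM to 25000 nM.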

Compound 4, half-maximal inhibitory concentration: 123000 nM
Estimate against measurement, compound 4: 11-fold (1.05 log units) below; the measured number lies above the stated range.
By their numbers in this assay, from the lowest: compound 3; then compounds 1 and 2 (each within the scatter of the next); then compound 4.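

In this assay, the exchange of phenyl for hydrogen on the amide-type nitrogen turns out to depend on the rest of the molecule: the chloro-bearing pair gave no step beyond the scatter, whereas the chloro-free pair gives a 15-fold higher number from compound 3 to compound 4 (1.17 log units; beyond the scatter), so the anilino group counts for far more on this core: the same change on two cores in this assay, a 1.3-fold higher number (0.11 log units; within the scatter) from compound 1 to compound 2 and a 15-fold higher number (1.17 log units; beyond the scatter) from compound 3 to compound 4, 11-fold (1.06 log units) apart, beyond the scatter of two such steps. The chloro exchange on the aromatic carbon also changes direction with the group on that nitrogen, giving a 2.8-fold higher number from compound 2 to compound 4 (0.45 log units; beyond the scatter) with amino in place, opposite in direction to the step seen with anilino: the same change on two cores in this assay, a 4.1-fold lower number (0.61 log units; beyond the scatter) from compound 1 to compound 3 and a 2.8-fold higher number (0.45 log units; beyond the scatter) from compound 2 to compound 4, 11-fold (1.06 log units) apart, beyond the scatter of two such steps. The two changes therefore do not add across these four compounds, and a step measured on one core cannot be carried over to the other.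

As far as these compounds go, whether this dependence extends beyond phenyl and hydrogen remains open, for instance with methyl or benzyl on the amide-type nitrogen, or with fluoro or methoxy in place of chloro on the aromatic carbon. Four values forming a single square of exchanges also leave open whether the same interplay would appear with a morpholine in place of the diethylamino group.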